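The source may report more compounds than this note shows. Statements on the series, on what has been measured and on what is new or still open speak of the compounds shown alone.

Compound 1 `Cc1cc(=O)n(-c2ccccc2C(F)(F)F)nc1C(=O)Nc1ccc(Oc2ncnc3ccsc23)c(F)c1` is one of three measured analogues sharing a core and differing on the aromatic nitrogen. In a functional assay on MCF7 cells (Homo sapiens) for cytotoxicity, read by MTT assay, with a stated time of 72 h (a lower number here means a stronger inhibitor, a higher number a weaker inhibitor), compound 1 gives 6020 nM. Compound 3 `Cc1cc(=O)n(-c2cccc(F)c2)nc1C(=O)Nc1ccc(Oc2ncnc3ccsc23)c(F)c1` gives 9050 nM in this assay, and compound 2 `Cc1cc(=O)n(-c2ccccc2OC(F)(F)F)nc1C(=O)Nc1ccc(Oc2ncnc3ccsc23)c(F)c1` gives 11500 nM, so the three sit together: a 1.5-fold higher number from compound 1 to compound 3 (0.18 log units; within the scatter) and a 1.9-fold higher number from compound 1 to compound 2 (0.28 log units; within the scatter). Compound 4 `Cc1cc(=O)n(-c2ccccc2C(F)(F)F)nc1C(=O)Nc1ccc(Oc2ncnc3sccc23)c(F)c1` instead changes the group on the oxygen: a group of 9 heavy atoms (6 carbon, 2 nitrogen, 1 sulfur; one five-membered aromatic ring with 1 hetero atom, one six-membered aromatic ring with 2 hetero atoms) in place of a group of 9 heavy atoms (6 carbon, 2 nitrogen, 1 sulfur; one five-membered aromatic ring with 1 hetero atom, one six-membered aromatic ring with 2 hetero atoms), on an oxygen on an aromatic ring. Among the compounds with values here, none of the measured steps touches that position, so nothing here speaks for a shift in either direction, and the expectation is that any step in this assay stays within the scatter. Compound 4 is therefore estimated at 6500 nM in this assay, with a range from 2200 nM to 19000 nM, which means an expected step of a 1.1-fold higher number from compound 1 to compound 4 (0.03 log units; within the scatter).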

Compound 4, half-maximal inhibitory concentration: 13800 nM
The estimate for compound 4 lay 2.1-fold (0.33 log units) below the measured number; measured number inside the range.
By their numbers in this assay, from the lowest: compounds 1, 3, 2 and 4 (each within the scatter of the next, the first and the last beyond it).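

At the group on the oxygen, the two attachments hold the same atoms joined differently, with the same printed counts of rings, donors and acceptors, yet in this assay this rearrangement alone gives a 2.3-fold higher number from compound 1 to compound 4 (0.36 log units; beyond the scatter). That makes this position the only one shown with a step beyond the scatter, as the steps on the aromatic nitrogen all stay within it. No supporting data bear on why the rearrangement has this effect. The compounds shown leave open whether the step would recur with 3-fluorophenyl on the aromatic nitrogen. From the compounds shown here alone, how an amine added to the group on the oxygen would read also remains open.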